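The source may hold more compounds than are shown below. What is called first, only, known or untested is meant among the compounds shown, and "the series" means these compounds.

Compound 1, `COc1ccc2nc(Nc3ccnc(Nc4ccc(S(N)(=O)=O)cc4)n3)sc2c1`, gives 11000 nM in a functional assay on MCF7 cells (Homo sapiens) for antiproliferative activity, read by MTT assay, with a stated time of 48 h; on this read-out lower numbers stand for stronger inhibition and higher numbers for weaker inhibition.
Compound 3, `Cc1ccc2nc(Nc3ccnc(Nc4ccc(S(N)(=O)=O)cc4)n3)sc2c1`, gives 5740 nM in this assay.
Compound 2, `Cc1cnc(Nc2ccc([N+](=O)[O-])cc2)nc1Nc1nc2ccccc2s1`, gives only a limit in this assay, namely > 50000 nM.

Among the measured compounds shown here, the one measured step that joins two numbers here is a 1.9-fold lower number from compound 1 to compound 3 (0.28 log units; within the scatter), a change on the benzothiazole side of the shared core. Compound 2 sits apart from those two: its result is the limit of > 50000 nM in this assay, at which 1 of the 3 values shown sits, so no number is known for it, only that it lies past the edge of what this assay reports.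

Compound 4, `Cc1cnc(Nc2ccc(C(C)C)cc2)nc1Nc1nc2ccccc2s1`, is built from compound 2 by a change on the other side of the core: isopropyl in place of nitro on an aromatic carbon. For the measured compounds named here, no measured step touches this position, and the single step that was measured alters a different ring with a different group, so it gives no guide to direction or size. The expectation therefore rests on the limit alone: compound 2 left no number, and a change elsewhere may or may not bring compound 4 back into the measurable range. Compound 4 is estimated at 30000 nM, with a range from 8000 nM to 150000 nM, which is expected to mean an at least 1.6-fold lower number from compound 2 to compound 4 (0.22 log units; that floor lies within the scatter), with a real chance that only a limit is reported again.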

Compound 4, half-maximal inhibitory concentration: > 50000 nM
Compound 4 ended at the assay's limit; the forecaster's own chance of this, stated with the estimate: 45%; middle value at least 1.6-fold (0.22 log units) away from the limit.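

No step can be read from compound 2 to compound 4, because both compounds end at a limit rather than a number: the limit of > 50000 nM in this assay, at which 2 of the 4 values shown sit.

The compounds shown leave open how far past that limit each of the two lies, and so whether isopropyl in place of nitro changes the result in this assay at all.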